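The source may hold more compounds than are shown below. What is called first, only, known or untested is meant among the compounds shown, and "the series" means these compounds.

Measured compounds:
compound 1, `CCCC(=O)NC(c1ccc(N(CC)CC)cc1)c1cc(Cl)c2cccnc2c1O`, 130 nM
compound 2, `O=C(NC(c1ccc(Cl)cc1Cl)c1ccc2cccnc2c1O)C1CCCC1`, 320 nM

Of the compounds shown here, two have been measured in a functional assay on A-375 cells (Homo sapiens) for antiproliferative activity, read by trypan blue exclusion and crystal violet staining, with a stated time of 72 h; a higher number here means a weaker inhibitor, a lower number a stronger inhibitor. Compound 1 `CCCC(=O)NC(c1ccc(N(CC)CC)cc1)c1cc(Cl)c2cccnc2c1O` gives 130 nM in this assay, the lower of the two numbers. Compound 2 `O=C(NC(c1ccc(Cl)cc1Cl)c1ccc2cccnc2c1O)C1CCCC1`, with a different amide and a different substitution pattern on both rings, gives 320 nM, a number that sits beyond the usual scatter of repeated measurements from that of compound 1. Within the data shown here, no pair of measured compounds differs in a single place, so no single change has yet been tied to a shift in this assay.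

Compound 3 `CCCC(=O)NC(c1ccc(C)cc1)c1cc(Cl)c2cccnc2c1O` has not been measured. It differs from compound 1 in one place: methyl in place of diethylamino on an aromatic carbon. Whether a smaller group in this position costs or gains activity cannot be read from compounds 1 and 2 alone. The account therefore expects a modest step from compound 1 to compound 3 towards a higher number, estimated as a 1.9-fold higher number from compound 1 to compound 3 (0.28 log units; within the scatter), possibly no larger than the scatter. For compound 3 the estimated value in this assay is 250 nM, within a range from 80 nM to 800 nM.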

Compound 3, half-maximal inhibitory concentration: 120 nM
Compound 3: middle estimate off by 2.1-fold (0.32 log units), on the high side, and the stated range covers the measured number.
By their numbers in this assay, from the lowest: compounds 3 and 1 (each within the scatter of the next); then compound 2.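

In this assay, methyl in place of diethylamino on this aromatic carbon, para to a large group, gives a 1.1-fold lower number from compound 1 to compound 3 (0.03 log units; within the scatter). The step lies within the scatter, so a group of 5 heavy atoms, with its nitrogen and its hydrogen-bond acceptor, can give way to a single carbon with no measurable change for this pair. The nitrogen and the acceptor that leave with diethylamino are therefore not needed to keep the activity of compound 1 in this assay, although no measurement shown here explains why the two groups read alike.

As far as these compounds go, only these two groups can be compared at this position, so it remains open whether a primary amine, a methoxy group, a chlorine atom or a carboxylic acid on the same carbon would also leave the number in place. From the compounds shown here alone, it is equally open whether methyl and diethylamino would still read alike if the butanamide of compounds 1 and 3 were replaced by another amide, such as a cyclopentyl amide.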